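Notes on amino-nitrogen substitution in a phosphorylated disaccharide series

This account rests on a few compounds, and the source may have more. Where it says the series, first, only, none or still open, it means among the compounds named here.

Measured compounds:
compound 1 `Nc1ncnc2c1ncn2C1O[C@H](CO)[C@H](O[C@@H]2OC(CO)[C@H](OP(=O)(O)O)C(OP(=O)(O)O)[C@@H]2O)[C@@H]1OP(=O)(O)O` — 1 nM
compound 2 `CNc1ncnc2c1ncn2C1O[C@H](CO)[C@H](O[C@@H]2OC(CO)[C@H](OP(=O)(O)O)C(OP(=O)(O)O)[C@@H]2O)[C@@H]1OP(=O)(O)O` — 0.8 nM

In a functional assay (Hepatocyte) with Rattus norvegicus as the target (on this read-out lower numbers stand for an effect already at smaller amounts and higher numbers for an effect only at larger amounts of compound), compound 1 gives 1 nM and compound 2 gives 0.8 nM. For the measured compounds named here, compound 1 holds the higher of the two numbers; the only step to it, a 1.3-fold lower number from compound 1 to compound 2 (0.10 log units; within the scatter), is within the scatter, so the two compounds cannot be ordered on this read-out.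

Compound 3 `O=P(O)(O)OC1[C@@H](OP(=O)(O)O)C(CO)O[C@@H](O[C@@H]2[C@H](OP(=O)(O)O)C(n3cnc4c(NC5CCCCC5)ncnc43)O[C@@H]2CO)[C@H]1O` is the next member awaiting measurement. It differs from compound 1 by cyclohexyl in place of hydrogen on a nitrogen on an aromatic ring. Going by the values given here, the single measured step that bears on this position, a 1.3-fold lower number from compound 1 to compound 2 (0.10 log units; within the scatter), shows that a small group on this nitrogen leaves the number unchanged within scatter. A cyclohexyl is a larger entering group than a methyl, and nothing measured here covers that size, so the expectation rests on one step only.

On that basis compound 3 is expected to show a 2.0-fold higher number from compound 1 to compound 3 (0.30 log units; within the scatter), at most a modest change. The estimate for compound 3 is 2 nM, with a range from 0.5 nM to 10 nM.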

Compound 3, half-maximal effective concentration: 0.56 nM
Compound 3: the middle estimate sits 3.6-fold (0.55 log units) above what was measured; the range from low to high includes it.
By their numbers in this assay, from the lowest: compounds 3, 2 and 1 (each within the scatter of the next).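

Cyclohexyl in place of hydrogen on this nitrogen gives a 1.8-fold lower number from compound 1 to compound 3 (0.25 log units; within the scatter) in this assay, and cyclohexyl in place of methyl gives a 1.4-fold lower number from compound 2 to compound 3 (0.15 log units; within the scatter). The earlier observation with methyl therefore extends to a much larger entering group: hydrogen, methyl and cyclohexyl cannot be ordered on this read-out, and no size effect appears among these three compounds. No available evidence explains this result.

Still open, on these data alone, is whether a phenyl ring, or a longer chain ending in an amine or a carboxylic acid, would also stay within the scatter at this nitrogen. Also open, as far as these compounds go, is whether a dimethylamino group, with no hydrogen left on the nitrogen, would do the same.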